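A few compounds are considered here, and "the series" means these few. Any claim that something is new, unique, unknown or untested is made for them only; others in the source may bear on it.

In a functional assay for inhibition of sodium/hydrogen exchanger (Oryctolagus cuniculus) (on this read-out higher numbers stand for weaker inhibition and lower numbers for stronger inhibition), three compounds have been measured so far. Compound 1 `CS(=O)(=O)c1cc(C(=O)N=C(N)N)c(F)cc1F` gives 630 nM, compound 2 `Cc1c(C(=O)N=C(N)N)cc(S(C)(=O)=O)c(Cl)c1Cl` gives 29 nM, and compound 3 `Cc1cc(C2CCC2)c(S(C)(=O)=O)cc1C(=O)N=C(N)N` gives 8.2 nM. Compound 3 thus stands lowest of the three numbers; compound 2 is nearest to it and lies beyond the scatter, while compound 1 is furthest and also beyond the scatter. Compound 4 `Cc1cc(SC(C)(C)C)c(S(C)(=O)=O)cc1C(=O)N=C(N)N` has not yet been measured in this assay. It differs from compound 3 in one place: (tert-butyl)sulfanyl in place of cyclobutyl on an aromatic carbon. Among the compounds with values here, no step between two measured compounds covers a change of this kind, so there is no direct guide. The step is expected to be small, a 1.5-fold higher number from compound 3 to compound 4 (0.17 log units; within the scatter), within the scatter or only just beyond it. Compound 4 is therefore estimated at 12 nM, with a range from 4 nM to 40 nM.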

Compound 4, half-maximal inhibitory concentration: 22 nM
Estimate against measurement, compound 4: 1.8-fold (0.26 log units) below; the range from low to high includes it.
By their numbers in this assay, from the lowest: compound 3; then compounds 4 and 2 (each within the scatter of the next); then compound 1.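

In this assay, the first step read at this aromatic carbon, ortho to the methylsulfonyl group, is a 2.7-fold higher number from compound 3 to compound 4 (0.43 log units; beyond the scatter), a modest rise on going from cyclobutyl to (tert-butyl)sulfanyl. The position therefore accepts a sulfur-linked group with no ring, at a measurable but limited cost. Nothing available bears on why the number rises. The compounds shown leave open whether the sulfur or the loss of the ring accounts for the step, which a plain tert-butyl or a cyclobutylsulfanyl group could separate. On these data alone, how an amine at this position would compare also remains open.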